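Cyclopropyl to ethoxymethyl: a stability forecast

The source may hold more compounds than are shown below. What is called first, only, known or untested is meant among the compounds shown, and "the series" means these compounds.

compound 1 `CCCCc1[nH]c(=O)c(-c2n[nH]c(Cc3ccccc3)n2)c(O)c1-c1c(OC)cccc1OC` gives 36%
compound 2 `CCCCc1[nH]c(=O)c(-c2nnc(Cc3ccccc3)o2)c(O)c1-c1c(OC)cccc1OC` gives 87%
compound 3 `COc1cccc(OC)c1-c1c(C2CC2)[nH]c(=O)c(-c2nnc(Cc3ccc(Cl)cc3)o2)c1O` gives 88%

All three numbers come from an ADME assay on microsomes from liver (Homo sapiens) for metabolic stability, read by mass spectrometry, using NADPH, with a stated time of 10 min (on this read-out lower numbers stand for a less stable compound and higher numbers for a more stable compound), and describe how much of each compound survives. Compound 3 at 88% stands level with compound 2 at 87% within the usual scatter, and both lie well clear of compound 1 at 36% on the low side.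

Compound 4 `CCOCc1[nH]c(=O)c(-c2nnc(Cc3ccc(Cl)cc3)o2)c(O)c1-c1c(OC)cccc1OC` is still to be measured. Compared with compound 3, it has ethoxymethyl in place of cyclopropyl on an aromatic carbon. Going by the values given here, no measured pair differs in one place only, so the data give no direct guide to this step, and no measured compound carries ethoxymethyl. Compound 1 at 36% shows that low numbers do occur in this small set. A moderate fall, somewhat beyond the scatter, is expected, and the estimated change is a number 14 percentage points lower from compound 3 to compound 4 (beyond the scatter) with real uncertainty around it. In this assay the estimate for compound 4 is 74% (range 52% to 90%).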

Compound 4, percent of the compound remaining: 94%
Compound 4: the middle estimate sits 20 percentage points below what was measured, outside the stated range (above it).
By their numbers in this assay, from the lowest: compound 1; then compounds 2, 3 and 4 (each within the scatter of the next).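

On the aromatic carbon next to the ring nitrogen, putting ethoxymethyl in place of cyclopropyl gives a number 6 percentage points higher from compound 3 to compound 4 (within the scatter) in this assay. Going by these compounds alone, this is the first direct reading at this position, since no earlier pair differed in one place only. It shows that a three-membered carbon ring can give way to an open chain carrying an oxygen without moving the read-out beyond the usual scatter, though no measurement here says why the number holds.

An amine or a carboxylic acid at this position, or a longer chain with the oxygen further out, could read quite differently, and these compounds give no hint either way. Going by these compounds, it also stays open whether the same swap would read alike in a compound without the chlorine.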